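Nitro versus hydroxymethyl on the distal ring of a biaryl alcohol series

This account rests on a few compounds, and the source may have more. Where it says the series, first, only, none or still open, it means among the compounds named here.

Measured compounds:
compound 1 `COc1cc(CC(O)c2ccc(-c3ccc([N+](=O)[O-])cc3)cc2)c([N+](=O)[O-])cc1OC` — 21000 nM
compound 2 `COc1cc(CC(O)c2ccc(-c3ccc(CO)cc3)cc2)c([N+](=O)[O-])cc1OC` — > 244000 nM
compound 3 `COc1cc(CC(O)c2ccc(-c3ccccc3[N+](=O)[O-])cc2)c([N+](=O)[O-])cc1OC` — 9500 nM

Three compounds on a shared core have been taken through an ADME assay on HeLa Rh cells (Homo sapiens) for cytotoxicity, read by microscopy; a lower number here means that less compound is tolerated, a higher number that more compound is tolerated. Compound 1 gives 21000 nM and compound 3 gives 9500 nM in this assay. The value of compound 2 in this assay is a limit of the assay, not a number: > 244000 nM.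

Compound 1 and compound 3 differ only in how the distal ring is joined: 2-nitrophenyl in place of 4-nitrophenyl on an aromatic carbon. That rearrangement gives a 2.2-fold lower number from compound 1 to compound 3 (0.34 log units; beyond the scatter).

The other change in the set is hydroxymethyl in place of nitro on an aromatic carbon. It gives an at least 11-fold higher number from compound 1 to compound 2 (1.06 log units; beyond the scatter); the step can only be given as a lower bound because of the limit of > 244000 nM in this assay, at which 1 of the 3 values shown sits. Between the two remaining compounds, an at least 25-fold lower number from compound 2 to compound 3 (1.40 log units; beyond the scatter).

Compound 4 `COc1cc(CC(O)c2ccc(-c3ccccc3CO)cc2)c([N+](=O)[O-])cc1OC` has not yet been run in this assay. It stands to compound 3 as compound 2 stands to compound 1: hydroxymethyl in place of nitro on an aromatic carbon. The surroundings differ, the group sitting ortho to a large group here against para to a large group before, so this is the same kind of change rather than the same change. The expectation rests on an at least 11-fold higher number from compound 1 to compound 2 (1.06 log units; beyond the scatter), and the step expected is a 13-fold higher number from compound 3 to compound 4 (1.10 log units; beyond the scatter). For compound 4 the expected value in this assay is 120000 nM, with a plausible span from 40000 nM to 300000 nM, and a real chance that only a limit is returned.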

Compound 4, half-maximal cytotoxic concentration: 24000 nM
The estimate for compound 4 lay 5.0-fold (0.70 log units) above the measured number; the measured number lies below the stated range.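

In this assay, hydroxymethyl in place of nitro, ortho to a large group, gives a 2.5-fold higher number from compound 3 to compound 4 (0.40 log units; beyond the scatter), so the direction seen with the change para to a large group holds in this second pair. The size of the change does not carry over from one core to the other: the same change on two cores in this assay, an at least 11-fold higher number (1.06 log units; beyond the scatter) from compound 1 to compound 2 and a 2.5-fold higher number (0.40 log units; beyond the scatter) from compound 3 to compound 4, at least 4.5-fold (0.66 log units) apart, beyond the scatter of two such steps

The remaining steps, an at least 10-fold lower number from compound 2 to compound 4 (1.00 log units; beyond the scatter) and a 1.1-fold higher number from compound 1 to compound 4 (0.06 log units; within the scatter), place compound 4 among the other compounds but do not show how far the first step truly reaches, and with only two pairs they give no rule for a further core: the limit of > 244000 nM in this assay, at which 1 of the 4 values shown sits.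

On these data alone, whether an amine or a carboxylic acid in place of nitro on the distal ring would follow hydroxymethyl in direction or size remains open, and so does whether a longer chain ending in hydroxyl would behave like hydroxymethyl. All four compounds also keep the nitro group on the shared core, so what that group contributes to the numbers in this assay is left open, as is whether the change would hold on a core without it.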